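A few compounds are considered here, and "the series" means these few. Any claim that something is new, unique, unknown or untested is made for them only; others in the source may bear on it.

Compound 1 `COc1cc(C)cc(-c2c(-c3ccnc(-c4ccc(C(C)=O)cc4)c3)cnn2CC#N)c1` is the point of departure. In a functional assay on SF-268 cells (Homo sapiens) for cytotoxicity, read by sulforhodamine B assay, with a stated time of 48 h, tested at 0.001 uM (a higher number here means a weaker effect of the compound at the concentration tested, a lower number a stronger effect), compound 1 gives 97%. Compound 3 `Cc1cc(O)cc(-c2nn(CC#N)cc2-c2ccnc(-c3ccc(N(C)C)cc3)c2)c1` gives 97% in this assay, level with compound 1 at the digits shown, and compound 2 `COc1cc(C)cc(-c2nn(CC#N)cc2-c2ccc(-c3cccc(C(C)=O)c3)nc2)c1` gives 99%, a difference that stays within the usual scatter. All three numbers therefore sit together at the weak end of the scale.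

Compound 4 `COc1cc(C)cc(-c2c(-c3ccnc(-c4ccc(N(C)C)cc4)c3)cnn2CC#N)c1` differs from compound 1 in one place: dimethylamino in place of acetyl on an aromatic carbon. Within the data shown here, no measured pair here shows this change on its own. Since compound 3, which carries the dimethylamino group on the same ring, gives 97%, the step from compound 1 to compound 4 is expected to be no change at the digits printed from compound 1 to compound 4 (within the scatter), nothing beyond the scatter. Compound 4 is estimated at 97%, within 90% to 101%.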

Compound 4, a percentage reported as activity, at one concentration (the size of the read-out at that concentration, not a potency): 98%
Compound 4: middle estimate off by 1 percentage points, on the low side, within the range that was stated.
By their numbers in this assay, from the lowest: compounds 1, 3, 4 and 2 (each within the scatter of the next).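

In this assay, replacing 4-acetylphenyl with 4-(dimethylamino)phenyl gives a number 1 percentage points higher from compound 1 to compound 4 (within the scatter) and so shows, for this change taken on its own, no effect beyond the scatter at this position. With both compounds at the weak end of the scale, this single concentration does not separate the two groups. Nothing available here bears on the result. From the compounds shown here alone, whether a carboxylic acid or a primary amine in the same place would move the read-out stays open. So does whether the two groups would differ at higher concentrations.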